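The source may report more compounds than this note shows. Statements on the series, on what has been measured and on what is new or still open speak of the compounds shown alone.

Working notes on the series. In an ADME assay on Vero cells (Chlorocebus sabaeus) for cytotoxicity, read by sulforhodamine B assay, with a stated time of 3 days (on this read-out higher numbers stand for lower toxicity in this test and lower numbers for higher toxicity in this test), compound 1 `CC1=C(C(=O)Nc2ccc(Cl)cc2)C(c2ccncc2)C(C(=O)Nc2ccc(Cl)cc2)=C(C)N1` gives 78 ug/mL. Compound 2 `CC1=C(C(=O)Nc2ccc(Cl)cc2)CC(C(=O)Nc2ccc(Cl)cc2)=C(C)N1` carries the change hydrogen in place of pyridin-4-yl on a saturated ring carbon and gives 40 ug/mL, a step of a 2.0-fold lower number from compound 1 to compound 2 (0.29 log units; within the scatter). Compound 3 `COc1ccc(NC(=O)C2=C(C)NC(=O)NC2c2ccncc2)cc1` gives 10 ug/mL; the difference between its core and the core of compound 1 is not broken down here. Compound 4 `COc1ccc(NC(=O)C2=C(C)NC(=O)NC2)cc1` is not yet measured; it differs from compound 3 by hydrogen in place of pyridin-4-yl on a saturated ring carbon. This is the same kind of change as that from compound 1 to compound 2, but the place differs: in compound 3 the saturated ring carbon lies in a ring with 2 nitrogen, next to the ring nitrogen and next to the ring atom that bears a large group, whereas in compound 1 it lies in a ring with 1 nitrogen, next to two ring atoms that each bear a (4-chlorophenyl)carbamoyl group. Because a 2.0-fold lower number from compound 1 to compound 2 (0.29 log units; within the scatter) stayed within the scatter, compound 4 is expected to shift from compound 3 by a 1.4-fold lower number from compound 3 to compound 4 (0.15 log units; within the scatter). The estimate for compound 4 is 7 ug/mL, between 3 ug/mL and 20 ug/mL.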

Compound 4, half-maximal cytotoxic concentration: 200 ug/mL
Beside the measured number, compound 4's estimate is 29-fold (1.46 log units) below it; the whole stated range lies below it.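

In this assay, hydrogen in place of pyridin-4-yl on a saturated ring carbon gives a 20-fold higher number from compound 3 to compound 4 (1.30 log units; beyond the scatter). The change does not carry over from the core of compound 1 to the core of compound 3 as a step of similar size in this test: the same change on two cores in this assay, a 2.0-fold lower number (0.29 log units; within the scatter) from compound 1 to compound 2 and a 20-fold higher number (1.30 log units; beyond the scatter) from compound 3 to compound 4, 39-fold (1.59 log units) apart, beyond the scatter of two such steps

The two cores differ in more than one place, and with one pair on each core the data do not show which difference sets the steps apart. As far as these compounds go, it remains open whether the large step on the core of compound 3 is tied to pyridin-4-yl or also appears with phenyl or a carboxylic acid on that saturated ring carbon. Also open, from the compounds shown here alone, is how a (4-chlorophenyl)carbamoyl group on that core would affect the step.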